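A few compounds are considered here, and "the series" means these few. Any claim that something is new, unique, unknown or untested is made for them only; others in the source may bear on it.

Measured compounds:
- compound 1 `C=C(Br)C(=O)Nc1ccc(/C=C2\SC(=O)N(Cc3cccc(F)c3)C2=O)cc1`: 1200 nM
- compound 2 `Nc1ccc(/C=C2\SC(=O)N(Cc3ccc(Cl)cc3)C2=O)cc1`: 37000 nM
- compound 3 `Nc1cccc(/C=C2\SC(=O)N(Cc3cccc(F)c3)C2=O)c1`: 199000 nM

All three values come from a functional assay on L1210 cells (Mus musculus) for cytotoxicity, read by cell counting, with a stated time of 2 days; on this read-out lower numbers stand for stronger inhibition and higher numbers for weaker inhibition. Compound 3 gives the highest number of the three; compound 2 sits nearest to it, and compound 1 is the furthest away, both gaps lying beyond the scatter. Compound 3 is therefore the weakest of the measured set in this assay.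

Compound 4 `Nc1ccc(/C=C2\SC(=O)N(Cc3cccc(F)c3)C2=O)cc1` has not yet been measured. It differs from compound 3 by 4-aminophenyl in place of 3-aminophenyl on a double-bonded chain carbon bound to a double-bonded ring carbon. Compound 2 carries the same 4-aminophenyl on the same double-bonded chain carbon, though with a different group on the ring nitrogen, and in this assay compound 2 gives 37000 nM, a much lower number than compound 3. On that basis a step toward lower numbers is expected, of about a 5.0-fold lower number from compound 3 to compound 4 (0.70 log units; beyond the scatter), placing compound 4 close to compound 2. The estimate for compound 4 is 40000 nM, with a range from 12000 nM to 130000 nM.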

Compound 4, half-maximal inhibitory concentration: 100000 nM
Compound 4: middle estimate off by 2.5-fold (0.40 log units), on the low side, and the stated range covers the measured number.
By their numbers in this assay, from the lowest: compound 1; then compound 2; then compounds 4 and 3 (each within the scatter of the next).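

The swap of 3-aminophenyl for 4-aminophenyl on a double-bonded chain carbon bound to a double-bonded ring carbon brings a 2.0-fold lower number from compound 3 to compound 4 (0.30 log units; within the scatter) in this assay and so shows no resolved preference between these two groups at this position. Compound 4 also makes two other single changes readable: 3-fluorophenyl in place of 4-chlorophenyl brings a 2.7-fold higher number from compound 2 to compound 4 (0.43 log units; beyond the scatter) and is a modest step. Hydrogen in place of (1-bromoethenyl)carbonyl on the nitrogen on the aromatic ring brings an 83-fold higher number from compound 1 to compound 4 (1.92 log units; beyond the scatter) and is by far the largest step in the series.

Still open, from the compounds shown here alone, is whether (1-bromoethenyl)carbonyl on 3-aminophenyl would give a number as low as that of compound 1, and whether an acetyl or chloroacetyl group on that nitrogen would do the same. No measured evidence bears on the reason for the size of any of these steps.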